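Chain-length series on a methoxy-acetophenone core

The source may report more compounds than this note shows. Statements on the series, on what has been measured and on what is new or still open speak of the compounds shown alone.

Measured so far:
compound 1, `CCCCCCCCCCCCCCOc1cc(OC)c(Br)cc1C(C)=O`, 8700000 nM
compound 2, `CCCCCCCCCCCCCCCCOc1cc(OC)c(Br)cc1C(C)=O`, 4600000 nM
compound 3, `CCCCCCCCOc1cc(OC)ccc1C(C)=O`, 38300000 nM

All three were run in a functional assay, read by spectrophotometry, with a stated time of 6 min; a lower number here means a stronger inhibitor, a higher number a weaker inhibitor. Compound 1 and compound 2 share a brominated core and differ by ethyl in place of hydrogen on a saturated chain carbon, ten or more bonds along the chain from an oxygen on an aromatic ring; the step is a 1.9-fold lower number from compound 1 to compound 2 (0.28 log units; within the scatter), so the two values cannot be ordered. Compound 3 carries a core without bromine; how its core differs from that of compound 1 is not broken down here. In this assay compound 3 gives 38300000 nM, the highest number of the three.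

Compound 4, `CCCCCCCCCCOc1cc(OC)ccc1C(C)=O`, is not yet measured. It differs from compound 3 by ethyl in place of hydrogen on a saturated chain carbon, eight bonds along the chain from an oxygen on an aromatic ring. This is the same kind of change as that from compound 1 to compound 2, though the place along the chain is not identical, as the two descriptions of the differences show. The expected step is a 1.9-fold lower number from compound 3 to compound 4 (0.28 log units; within the scatter), resting on the earlier step being a 1.9-fold lower number from compound 1 to compound 2 (0.28 log units; within the scatter) and on compound 3 standing at 38300000 nM. Compound 4 is therefore expected to give about 20000000 nM, with a range estimated from 8000000 nM to 45000000 nM.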

Compound 4, half-maximal inhibitory concentration: 41700000 nM
Estimate against measurement, compound 4: 2.1-fold (0.32 log units) below; the range from low to high includes it.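

In this assay the new step reads a 1.1-fold higher number from compound 3 to compound 4 (0.04 log units; within the scatter), so the added ethyl gives no order between these two compounds, as on the brominated core. Set beside the earlier step, the new step shows no difference between the two cores: the same change on two cores in this assay, a 1.9-fold lower number (0.28 log units; within the scatter) from compound 1 to compound 2 and a 1.1-fold higher number (0.04 log units; within the scatter) from compound 3 to compound 4, 2.1-fold (0.31 log units) apart, within the scatter of two such steps. This is consistent with the change carrying from one core to the other in this assay, but with both steps inside the scatter it does not show that the change moves the number on either core, and two pairs cannot establish a rule for the series.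

Still open, on these data alone, is whether a chain ending in an amine or a carboxylic acid, or a much shorter chain such as butyl, would give a step beyond the scatter on either core. As far as these compounds go, the part played by the bromine also stays open, as the brominated compounds and those without bromine also carry different chains.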